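Methoxy added to the dimethoxyphenyl ketone of compound 2

This account rests on a few compounds, and the source may have more. Where it says the series, first, only, none or still open, it means among the compounds named here.

Three pyrazolyl chalcones were measured in a functional assay on OVCAR-4 cells (Homo sapiens) for cytotoxicity, read by sulforhodamine B assay, with a stated time of 48 h, tested at 0.01 uM; a higher number here means a weaker effect of the compound at the concentration tested, a lower number a stronger effect. Compound 1 `COc1cc(-c2cc(/C=C/C(=O)c3ccc(Cl)c(Cl)c3)[nH]n2)cc(OC)c1OC` gives 92%, compound 2 `COc1ccc(C(=O)/C=C/c2cc(-c3cc(OC)c(OC)c(OC)c3)n[nH]2)cc1OC` gives 95%, and compound 3 `COc1ccc(C(=O)/C=C/c2cc(-c3cc(OC)c(OC)c(OC)c3)n[nH]2)cc1` gives 91%. Compound 2 sits at the upper end of the three, yet a number 3 percentage points higher from compound 1 to compound 2 (within the scatter) and a number 4 percentage points lower from compound 2 to compound 3 (within the scatter), so the three numbers cannot be told apart; a number 1 percentage points lower from compound 1 to compound 3 (within the scatter) likewise. Compound 4 `COc1cc(C(=O)/C=C/c2cc(-c3cc(OC)c(OC)c(OC)c3)n[nH]2)cc(OC)c1OC` differs from compound 2 by methoxy in place of hydrogen on an aromatic carbon. The reverse change, loss of a methoxy, is seen in the step from compound 2 to compound 3, and the aryl swaps from compound 1 also stayed within the scatter, so no step beyond the scatter is expected in this assay. Compound 4 is therefore estimated at 93%, range 84% to 100%, an expected a number 2 percentage points lower from compound 2 to compound 4 (within the scatter).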

Compound 4, a percentage reported as activity, at one concentration (the size of the read-out at that concentration, not a potency): 95%
The estimate for compound 4 lay 2 percentage points below the measured number; the range from low to high includes it.
By their numbers in this assay, from the lowest: compounds 3, 1, 2 and 4 (each within the scatter of the next).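

In this assay, methoxy in place of hydrogen on this aromatic carbon, ortho to a methoxy group and meta to a large group, gives no change at the digits printed from compound 2 to compound 4 (within the scatter). Alongside a number 4 percentage points lower from compound 2 to compound 3 (within the scatter), this shows that both adding and removing a methoxy on this ring leave the read-out within the scatter. No measurement bears on why the change left the number as it was.

As far as these compounds go, whether an amine or a carboxylic acid at this position would give a step beyond the scatter stays open. So does whether these compounds would separate at other concentrations.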